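Phenyl in place of 3-methoxybenzyl on the shared core

The source may hold more compounds than are shown below. What is called first, only, known or untested is meant among the compounds shown, and "the series" means these compounds.

Among the measured compounds shown here, compound 2 `C=C(Br)C(=O)Nc1cccc(-c2cn3nc(Cc4cccc(OC)c4)sc3n2)c1` gives 3100 nM in a functional assay on CCRF-CEM cells (Homo sapiens) for inhibition, read by cell counting, with a stated time of 3 days (a higher number here means a weaker inhibitor, a lower number a stronger inhibitor), the highest of the two numbers so far. For the measured compounds named here, compound 1 `C=C(Br)C(=O)Nc1cccc(-c2cn3nc(-c4ccc(F)cc4)sc3n2)c1` gives 830 nM in this assay; the only step measured is a 3.7-fold higher number from compound 1 to compound 2 (0.57 log units; beyond the scatter), modest but beyond the scatter. Compound 3 `C=C(Br)C(=O)Nc1cccc(-c2cn3nc(-c4ccccc4)sc3n2)c1` differs from compound 2 by phenyl in place of 3-methoxybenzyl on an aromatic carbon. Going by the values given here, no measured step involves this phenyl directly; the one comparison that bears on it is the step between compound 1 and compound 2, where a six-membered aromatic ring attached directly to the core sat at the lower number and the benzyl variant at the higher. Compound 3 carries such a directly attached ring, so a step of a 3.1-fold lower number from compound 2 to compound 3 (0.49 log units; beyond the scatter) back toward the number of compound 1 is expected, about the size of that earlier step. Compound 3 is therefore estimated at 1000 nM, in a range from 400 nM to 2500 nM.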

Compound 3, half-maximal inhibitory concentration: 960 nM
Estimate against measurement, compound 3: 1.0-fold (0.02 log units) above; the measured number falls inside the stated range.
By their numbers in this assay, from the lowest: compounds 1 and 3 (each within the scatter of the next); then compound 2.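

With phenyl in place of 3-methoxybenzyl, this assay gives a 3.2-fold lower number from compound 2 to compound 3 (0.51 log units; beyond the scatter) and so shows that the separation between the directly attached ring and the benzyl variant does not depend on the fluoro of compound 1. Hydrogen in place of fluoro gives a 1.2-fold higher number from compound 1 to compound 3 (0.06 log units; within the scatter) and leaves 4-fluorophenyl and phenyl indistinguishable at this aromatic carbon of the shared core. Together, the two steps put the difference at this position with the change from 3-methoxybenzyl to a directly attached ring rather than with the fluoro.

Compound 2 differs from compound 3 in both its linking carbon and its methoxy, so the shown compounds cannot assign its higher number to either feature. What an amine or a carboxylic acid on the phenyl would do here also remains open, and no measurement at hand gives a cause for either step.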